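Shifting a Chlorine on a Sulfonamide Series

This account rests on a few compounds, and the source may have more. Where it says the series, first, only, none or still open, it means among the compounds named here.

Compound 1 `O=S(=O)(Nc1ccc2oc(-c3ccccc3)nc2c1)c1ccc(Cl)c(Cl)c1`: > 63000 nM
Compound 2 `O=S(=O)(Nc1ccc(-c2nc3ccccc3o2)cc1)c1cccc(Cl)c1`: > 63000 nM
Compound 3 `O=S(=O)(Nc1ccc2oc(-c3ccccc3)nc2c1)c1ccc(O)cc1`: > 63000 nM

In an assay on isolated protein for inhibition of malate dehydrogenase, mitochondrial (Sus scrofa), with stated times of 45 min and 30 min (on this read-out higher numbers stand for weaker inhibition and lower numbers for stronger inhibition), compound 1 gives > 63000 nM, which is a limit of the assay rather than a number. Compound 2 likewise reaches only the limit > 63000 nM. Compound 3 also sits at the limit > 63000 nM. Hence a step that the two limits leave unreadable from compound 1 to compound 3 cannot be read, and the limit of > 63000 nM in this assay, at which 3 of the 3 values shown sit, shows that every value so far stands at that same limit. Compound 4 `O=S(=O)(Nc1ccc(-c2nc3ccccc3o2)cc1)c1ccc(Cl)cc1` is still to be measured; it differs from compound 2 by 4-chlorophenyl in place of 3-chlorophenyl on a sulfonyl sulfur. For the measured compounds named here, no measured step reports a readable change for any swap of this kind, so no step beyond the scatter is expected in this assay, and the move a step that the limit leaves unreadable from compound 2 to compound 4 is an expectation only. Compound 4 is estimated at 80000 nM, between 40000 nM and 200000 nM.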

Compound 4, half-maximal inhibitory concentration: > 63000 nM
Compound 4: only a limit was reported; the forecaster's own chance of this, stated with the estimate: 85%; the middle value is on the limit's open side.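

Compound 4 gives > 63000 nM as a limit and not a number, and no step can be read from compound 2 to compound 4: the limit of > 63000 nM in this assay, at which 4 of the 4 values shown sit. The compounds shown leave open whether any change to this series gives a readable inhibition.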